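Two fused cores and one methyl removed

This account rests on a few compounds, and the source may have more. Where it says the series, first, only, none or still open, it means among the compounds named here.

Of the compounds shown here, three have been measured in a functional assay on THP-1 cells (Homo sapiens) for cytotoxicity, read by MTT assay, with a stated time of 48 h; a lower number here means a stronger inhibitor, a higher number a weaker inhibitor. Compound 1 `Cc1ccc2nc(Nc3nc4ccccc4s3)sc2c1` gives 34200 nM in this assay. Compound 3 `c1ccc2sc(Nc3nc4ccccc4s3)nc2c1` gives 28800 nM in this assay, and the change hydrogen in place of methyl on an aromatic carbon produced a 1.2-fold lower number from compound 1 to compound 3 (0.07 log units; within the scatter). Compound 2 `Cc1ccc2nc(NC(=S)Nc3ccccc3)sc2c1` gives only > 50000 nM in this assay, which is a limit and not a number. Compound 2 sits at the limit of > 50000 nM in this assay, at which 1 of the 3 values shown sits. The difference between the core of compound 1 and the core of compound 2 is not broken down here. Compound 4 `S=C(Nc1ccccc1)Nc1nc2ccccc2s1` remains to be measured in this assay, and it differs from compound 2 by hydrogen in place of methyl on an aromatic carbon, the same change as from compound 1 to compound 3. Compound 4 is expected to give 70000 nM, because the same change gave a 1.2-fold lower number from compound 1 to compound 3 (0.07 log units; within the scatter). The expected step is a step that the limit leaves unreadable from compound 2 to compound 4, and a limit rather than a number is thought likely for compound 4.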

Compound 4, half-maximal inhibitory concentration: 36500 nM
Estimate against measurement, compound 4: 1.9-fold (0.28 log units) above; measured number inside the range.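

In this assay, hydrogen in place of methyl on an aromatic carbon gives an at least 1.3-fold lower number from compound 2 to compound 4 (0.13 log units; that floor lies within the scatter). Compound 2 gives > 50000 nM, which is a limit of the assay and not a number, so this step has only a floor and no exact size. Nothing here suggests that the change acts differently on the two cores, but the data do not show that it carries over unchanged either: the same change on two cores in this assay, a 1.2-fold lower number (0.07 log units; within the scatter) from compound 1 to compound 3 and an at least 1.3-fold lower number (0.13 log units; that floor lies within the scatter) from compound 2 to compound 4; the limit leaves it open whether they differ

The compounds shown leave open what an amine or a carboxylic acid on that aromatic carbon would give in this assay. They also leave open whether the same change would read alike on any further core.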